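Compound 3 to compound 4: swapping the aryl group

The source may hold more compounds than are shown below. What is called first, only, known or untested is meant among the compounds shown, and "the series" means these compounds.

In a functional assay on MDA-MB-231 cells (Homo sapiens), read by microscopy and transwell migration, with a stated time of 24 h (on this read-out lower numbers stand for stronger inhibition and higher numbers for weaker inhibition), compound 1 `C#CCn1c(-c2ccc(C)cc2C)cs/c1=N\C(=O)c1ccccc1` gives 3890 nM, compound 2 `C=CCn1c(-c2ccccc2)cs/c1=N\C(=O)c1ccccc1` gives 1200 nM and compound 3 `O=C(Nc1nc(-c2ccccc2Cl)cs1)c1ccccc1` gives 15000 nM. Compound 3 therefore has the highest of the three numbers, and its gaps to both others lie beyond the scatter.

The next structure is compound 4 `O=C(Nc1nc(-c2ccc(Br)cc2)cs1)c1ccccc1`, with the change 4-bromophenyl in place of 2-chlorophenyl on an aromatic carbon of a five-membered aromatic ring with 1 nitrogen and 1 sulfur. Compound 1 and compound 2 differ from compound 3 in more than one place, so neither gives a direct measure of this change. The expectation therefore starts from compound 3 at 15000 nM, and the data offer no firm direction. The expected result in this assay is a 1.5-fold lower number from compound 3 to compound 4 (0.18 log units; within the scatter), a small move to a lower number and no step beyond the scatter. For compound 4 the estimated value is 10000 nM, with an expected range of 3500 nM to 30000 nM.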

Compound 4, half-maximal inhibitory concentration: 9500 nM
Compound 4: middle estimate off by 1.1-fold (0.02 log units), on the high side; low and high end bracket the measured number.
By their numbers in this assay, from the lowest: compound 2; then compound 1; then compounds 4 and 3 (each within the scatter of the next).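

In this assay, 4-bromophenyl in place of 2-chlorophenyl on an aromatic carbon of the shared core gives a 1.6-fold lower number from compound 3 to compound 4 (0.20 log units; within the scatter), the first direct measure of a change at this position. Going by these compounds alone, this swap keeps the count of 7 heavy atoms in the aryl group but changes both the halogen and its place on the phenyl ring, so the single step does not separate the two changes. No measurement shown gives a reason for this result.

On these data alone, the separate contributions of halogen and ring placement remain open, and 4-chlorophenyl or 2-bromophenyl at this carbon would address them. Also open, as far as these compounds go, is how the same position responds to a group of another kind, such as a carboxylic acid or an amine on the phenyl ring.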